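Aryl exchange on the sulfonyl sulfur, compound 3 onward

The source may report more compounds than this note shows. Statements on the series, on what has been measured and on what is new or still open speak of the compounds shown alone.

Measured so far in a functional assay on LNCaP cells (Homo sapiens) for antiproliferative activity, read by propidium iodide staining, with a stated time of 96 h (on this read-out higher numbers stand for weaker inhibition and lower numbers for stronger inhibition), for three compounds:
compound 1 `CC(O)(CSc1ccc(S(F)(F)(F)(F)F)cc1)C(=O)Nc1ccc(S(F)(F)(F)(F)F)cc1` gives 18300 nM
compound 2 `CC(O)(CS(=O)(=O)c1ccc(S(F)(F)(F)(F)F)cc1)C(=O)Nc1ccc(S(F)(F)(F)(F)F)cc1` gives 29200 nM
compound 3 `CC(O)(CS(=O)(=O)c1ccc(C(F)(F)F)cc1)C(=O)Nc1ccc(S(F)(F)(F)(F)F)cc1` gives 20700 nM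

All three values lie within the scatter of one another. Compound 3 at 20700 nM therefore sits in one band with compound 1 and compound 2, and no order can be read among them.

Next in the series is compound 4 `CC(O)(CS(=O)(=O)c1cccc(OC(F)(F)F)c1)C(=O)Nc1ccc(S(F)(F)(F)(F)F)cc1` which has not yet been measured. Relative to compound 3 the change is 3-(trifluoromethoxy)phenyl in place of 4-(trifluoromethyl)phenyl on a sulfonyl sulfur and the rest of the structure stays the same.

Among the compounds with values here, one measured step bears on this change, an exchange of a group on an aromatic carbon of the group held by the sulfonyl sulfur. That step is a 1.4-fold lower number from compound 2 to compound 3 (0.15 log units; within the scatter) and it stays within the scatter. Within the data shown here, no measured compound carries the 3-(trifluoromethoxy)phenyl group, so the evidence is indirect and the range is kept wide.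

The expected step in this assay is a 1.0-fold lower number from compound 3 to compound 4 (0.01 log units; within the scatter) and none beyond the scatter is expected. For compound 4 the estimated value is 20000 nM with an expected range from 9000 nM to 45000 nM in this assay.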

Compound 4, half-maximal inhibitory concentration: 21700 nM
Beside the measured number, compound 4's estimate is 1.1-fold (0.04 log units) below it, within the range that was stated.
By their numbers in this assay, from the lowest: compounds 1, 3, 4 and 2 (each within the scatter of the next).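

In this assay, a 1.0-fold higher number from compound 3 to compound 4 (0.02 log units; within the scatter), so replacing 4-(trifluoromethyl)phenyl with 3-(trifluoromethoxy)phenyl on a sulfonyl sulfur gives no readable change, even though the entering group brings an oxygen and a hydrogen-bond acceptor and its substituent stands at a different ring position. Together with the earlier exchange on the same aryl group, a 1.4-fold lower number from compound 2 to compound 3 (0.15 log units; within the scatter), this gives two changes at this position that both stay within the scatter, and compound 2, compound 3 and compound 4 therefore cannot be ordered. Nothing measured here offers an explanation for this flat result.

Because the substituent and its ring position change together between compound 3 and compound 4, their separate contributions remain unresolved, and they could even offset each other. All of the aryl groups shown on the sulfonyl sulfur carry fluorinated substituents, so it remains open whether an unsubstituted phenyl, an amine or a carboxylic acid at this position would move the number beyond the scatter.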